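The compounds below may be only part of what the source reports. "The series", "measured", "known", "first", "only" and "open" are said of these compounds alone.

Of the compounds shown here, three built on one shared core have been measured in a functional assay on PC-3 cells (Homo sapiens) for inhibition, read by MTT assay, with a stated time of 72 h; on this read-out higher numbers stand for weaker inhibition and lower numbers for stronger inhibition. Compound 1 `C#CCSc1nc(NCCC#N)c2ccncc2n1` carries a 2-cyanoethyl group on a nitrogen of the core. In this assay compound 1 gives > 80000 nM, which is a limit of the assay and not a number. Compound 2 `C#CCSc1nc(Nc2ccccc2)c2ccncc2n1` carries a phenyl group in place of that 2-cyanoethyl group. In this assay compound 2 gives > 80000 nM, again a limit of the assay rather than a number, so that compound 2 stands at the limit of > 80000 nM in this assay, at which 2 of the 3 values shown sit. Compound 3 `C#CCSc1nc(Nc2ccc(F)cc2)c2ccncc2n1` carries a 4-fluorophenyl group, and in this assay compound 3 gives 17300 nM. Of the measured steps, a step that the two limits leave unreadable from compound 1 to compound 2 tells nothing about size, whereas an at least 4.6-fold lower number from compound 1 to compound 3 (0.66 log units; beyond the scatter) and an at least 4.6-fold lower number from compound 2 to compound 3 (0.66 log units; beyond the scatter) both move downward.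

Compound 4 `C#CCSc1nc(Nc2ccc([N+](=O)[O-])cc2)c2ccncc2n1` differs from compound 2 by nitro in place of hydrogen on an aromatic carbon. Among the compounds with values here, the one measured step that bears on this change is an at least 4.6-fold lower number from compound 2 to compound 3 (0.66 log units; beyond the scatter), a group entering on an aromatic carbon of the same phenyl ring. On that footing compound 4 is expected to give a lower number than the limit at which compound 2 sits, by roughly an at least 4.0-fold lower number from compound 2 to compound 4 (0.60 log units; beyond the scatter). Compound 4 is accordingly estimated at 20000 nM, with a range from 5000 nM to 80000 nM.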

Compound 4, half-maximal inhibitory concentration: > 80000 nM
Compound 4: no number, only a limit; the forecaster's own chance of this, stated with the estimate: 35%; middle value at least 4.0-fold (0.60 log units) away from the limit.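

In this assay, the aromatic carbon para to a large group does not respond in the same way to every group that enters there: with nitro in place of fluoro on that carbon, the series shows an at least 4.6-fold higher number from compound 3 to compound 4 (0.66 log units; beyond the scatter). The change from hydrogen to nitro itself cannot be read, as compound 2 and compound 4 both stand at limits of the assay and neither gives a number. Compound 3 thus remains the only one of the four with a number, and compound 4 joins the others there: the limit of > 80000 nM in this assay, at which 3 of the 4 values shown sit.

What the compounds shown leave open is whether the lower number of compound 3 belongs to fluoro alone or would also appear with other groups on that same carbon, such as chloro, methoxy or an amine. Also open, going by these compounds, is how the number would move if a carboxylic acid or a longer chain stood on the nitrogen of the shared core in place of the 4-fluorophenyl group of compound 3.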